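Swapping the aryl group on the imine of compound 2

The source may hold more compounds than are shown below. What is called first, only, known or untested is meant among the compounds shown, and "the series" means these compounds.

Compound 2 `CN(C)c1ccc(/C=N/C2=C(C#N)C(c3ccc(Cl)cc3Cl)C3=C(CCCC3=O)N2c2ccc(S(N)(=O)=O)cc2)cc1` gives 40% in a functional assay on Ehrlich cells (Mus musculus) for cytotoxicity, read by trypan blue exclusion, with a stated time of 2 h, tested at 100 ug/mL (a lower number here means a weaker effect, a higher number a stronger effect of the compound at the concentration tested), the lowest of two numbers: compound 1 `N#CC1=C(NC(=O)/C=C/c2ccccc2)N(c2ccc(S(N)(=O)=O)cc2)C2=C(C(=O)CCC2)C1c1ccc(Cl)cc1Cl` gives 45% in this assay, and the step of a number 5 percentage points lower from compound 1 to compound 2 (within the scatter) lies within the scatter. Compound 3 `N#CC1=C(/N=C/c2ccc([N+](=O)[O-])cc2[N+](=O)[O-])N(c2ccc(S(N)(=O)=O)cc2)C2=C(C(=O)CCC2)C1c1ccc(Cl)cc1Cl` differs from compound 2 by 2,4-dinitrophenyl in place of 4-(dimethylamino)phenyl on a carbon with a double bond to nitrogen. Going by the values given here, no measured step changes that aryl group; the only step, from compound 1 to compound 2, altered a different part and stayed within the scatter. No step beyond the scatter is therefore expected here, and the estimated step of no change at the digits printed from compound 2 to compound 3 (within the scatter) is small. Compound 3 is expected to give 40%, between 25% and 55%.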

Compound 3, a percentage reported as activity, at one concentration (the size of the read-out at that concentration, not a potency): 20%
Estimate against measurement, compound 3: 20 percentage points above, and the stated range ends above it.
By their numbers in this assay, from the lowest: compound 3; then compounds 2 and 1 (each within the scatter of the next).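

On a carbon with a double bond to nitrogen, 2,4-dinitrophenyl in place of 4-(dimethylamino)phenyl gives a number 20 percentage points lower from compound 2 to compound 3 (beyond the scatter) in this assay. This is the first change shown to move the read-out beyond the scatter, so the aryl group at this position matters for the effect at the concentration tested. Nothing available gives a reason for the drop. Going by these compounds alone, with only two aryl groups compared here, it remains open whether 4-nitrophenyl or 4-methoxyphenyl would read closer to compound 2 or to compound 3. A single concentration also leaves potency unknown.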